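The compounds below may be only part of what the source reports. "The series", "measured", "known", "first", "only" and "open" are said of these compounds alone.

Measured compounds in the series:
compound 1 `Cc1n[nH]cc1-c1cccc2c1CCC2c1ncc[nH]1`: 91%
compound 2 `c1cc(-c2ccn[nH]2)c2c(c1)C(c1ncc[nH]1)CC2`: 83%
compound 3 `Cn1nccc1-c1cccc2c1CCC2c1ncc[nH]1`: 58%

In a functional assay on CHO cells for agonist activity at Alpha-1A adrenergic receptor (Homo sapiens), read by FLIPR and calcium flux (on this read-out lower numbers stand for smaller maximal responses and higher numbers for larger maximal responses), compound 3 stands lowest of the three numbers. The steps of a number 33 percentage points lower from compound 1 to compound 3 (beyond the scatter) and a number 25 percentage points lower from compound 2 to compound 3 (beyond the scatter) both lie beyond the scatter, whereas a number 8 percentage points lower from compound 1 to compound 2 (within the scatter) does not, so the drop is tied to compound 3 alone. Compound 4 `Cc1oncc1-c1cccc2c1CCC2c1ncc[nH]1` is the next step: 5-methyl-1,2-oxazol-4-yl in place of 1-methyl-1H-pyrazol-5-yl on an aromatic carbon. The entering ring, like the ring of compound 1, bears its methyl on the ring itself rather than on a ring nitrogen, and removal of the methyl from the ring nitrogen in the step from compound 2 to compound 3 is what lowered the maximal response. A partial recovery is therefore expected, of modest size. Compound 4 is estimated at 75% (range 55% to 95%), an expected step of a number 17 percentage points higher from compound 3 to compound 4 (beyond the scatter).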

Compound 4, largest response reached (Emax), in percent of the reference or control that the assay uses: 63%
Estimate against measurement, compound 4: 12 percentage points above, within the range that was stated.
By their numbers in this assay, from the lowest: compounds 3 and 4 (each within the scatter of the next); then compounds 2 and 1 (each within the scatter of the next).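

In this assay, moving the methyl from a ring nitrogen to a ring carbon does not restore the response at this aromatic carbon, with 5-methyl-1,2-oxazol-4-yl giving a number 5 percentage points higher from compound 3 to compound 4 (within the scatter). Among these compounds, the new ring also falls short of both 1H-pyrazole groups, with a number 20 percentage points lower from compound 2 to compound 4 (beyond the scatter) and a number 28 percentage points lower from compound 1 to compound 4 (beyond the scatter); across these four compounds, the higher responses belong to the two rings with a hydrogen on a ring nitrogen, and no compound goes against this. No measured evidence explains this difference. Still open, from the compounds shown here alone, is whether that ring hydrogen is itself what matters, and how a 1H-1,2,3-triazol-4-yl or an aminomethyl group would behave at this position.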